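Adding a Nitro Group: Where Lipophilicity Might Land

The source may report more compounds than this note shows. Statements on the series, on what has been measured and on what is new or still open speak of the compounds shown alone.

Measured so far:
Compound 1, `C/C(CC(=O)Nc1nnc(-c2ccc(O)cc2)s1)=N\c1ccccn1`: 3.43
Compound 2, `CC(=O)Oc1ccccc1-c1nnc(NC(=O)C/C(C)=N/c2ccccn2)s1`: 3.65

Of the compounds shown here, two have been measured in a physicochemical assay for lipophilicity, measured as octanol-water partition; a higher number here means a more lipophilic compound, a lower number a more polar compound. Compound 1, with the structure `C/C(CC(=O)Nc1nnc(-c2ccc(O)cc2)s1)=N\c1ccccn1`, gives 3.43 in this assay. Compound 2, with the structure `CC(=O)Oc1ccccc1-c1nnc(NC(=O)C/C(C)=N/c2ccccn2)s1`, gives 3.65. Of the two numbers shown, compound 2 carries the larger, but compound 1 sits so close to it that the gap falls within the scatter of repeated measurements; the two cannot be told apart on this evidence.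

Compound 3, `CC(=O)Oc1ccccc1-c1nnc(NC(=O)C/C(C)=N/c2ccc([N+](=O)[O-])cn2)s1`, has not yet been measured. It differs from compound 2 in one place: nitro in place of hydrogen on an aromatic carbon. Going by the values given here, no measured pair in this set shares that kind of change, so there is no step to lean on. With no comparison to draw upon, the expectation rests on the small size of the change alone: a step in either direction that stays within the scatter, or none at all. The expected step is a number 0.15 log units lower from compound 2 to compound 3 (within the scatter). Compound 3 is therefore estimated at 3.5, with a range from 3 to 4.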

Compound 3, partition coefficient: 3.56
Compound 3: the middle estimate sits 0.06 log units below what was measured; measured number inside the range.
By their numbers in this assay, from the lowest: compounds 1, 3 and 2 (each within the scatter of the next).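

Going by these compounds alone, changing pyridin-2-yl to 5-nitropyridin-2-yl gives the first step in this set that can be read in this assay, and that step is a number 0.09 log units lower from compound 2 to compound 3 (within the scatter) and nothing larger. Within the data shown here, this is the first look at this position, two atoms from the ring nitrogen and para to a large group, and it shows that a nitro group of 3 heavy atoms and no net charge can replace a hydrogen there without a shift that stands clear of the usual scatter, at least on the background of compound 2. Nothing measured here explains why the step stays this small, since no supporting data on the nitro group or on this position are available.

A single pair also cannot show whether this small step is typical of the position or particular to nitro, so an amine, a carboxylic acid or a methoxy group at the same carbon could give a quite different result. On these data alone, it also remains open whether nitro would behave in the same way at another carbon of that ring, or on the background of compound 1.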